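Replacing the five-membered ring group of compound 1

The source may hold more compounds than are shown below. What is called first, only, known or untested is meant among the compounds shown, and "the series" means these compounds.

In a functional assay on HT-29 cells (Homo sapiens) for inhibition, read by sulforhodamine B assay, with a stated time of 48 h (on this read-out higher numbers stand for weaker inhibition of growth and lower numbers for stronger inhibition of growth), compound 1 `c1cc(NC2=NCCO2)cc(OC2CCCCCC2)c1` gives 6900 nM and compound 2 `Cc1ccc(NC2=NCCO2)cc1` gives 13000 nM and the two stand within the scatter of each other. Compound 3 `O=C(CCl)NC(=O)Nc1cccc(OC2CCCCCC2)c1` departs from compound 1 through a group of 7 heavy atoms (3 carbon, 1 nitrogen, 2 oxygen, 1 chlorine; no ring) in place of a group of 5 heavy atoms (3 carbon, 1 nitrogen, 1 oxygen; one five-membered non-aromatic ring with 2 hetero atoms), on a nitrogen on an aromatic ring and keeps the rest of the structure. No measured step sizes this change in this assay so the expectation is only a small move toward stronger inhibition of growth, estimated as a 2.3-fold lower number from compound 1 to compound 3 (0.36 log units; beyond the scatter) with wide uncertainty. Compound 3 is estimated at 3000 nM with an expected range from 1000 nM to 9000 nM once measured.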

Compound 3, concentration for 50% growth inhibition: 6900 nM
Compound 3: the middle estimate sits 2.3-fold (0.36 log units) below what was measured, and the stated range covers the measured number.
By their numbers in this assay, from the lowest: compounds 1, 3 and 2 (each within the scatter of the next).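

On a nitrogen on an aromatic ring, putting ((chloromethyl)carbonyl)carbamoyl in place of the five-membered non-aromatic ring group gives no change at the digits printed from compound 1 to compound 3 (within the scatter) in this assay. At this place, then, a group with no ring reads the same as the ring group on the shared core, a first step measured at this position. Nothing measured here speaks to why the two groups read alike. Still open, going by these compounds, is whether the chlorine counts, which a plain methyl in place of the chloromethyl would test, and how a free amine at the same place would read.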